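Removing the fluoro group from compound 2

The compounds below may be only part of what the source reports. "The series", "measured", "known", "first", "only" and "open" are said of these compounds alone.

compound 1 `C=CC(=O)Nc1cc(Nc2ncc(I)c(Nc3ccccc3S(=O)(=O)N(C)C)n2)c(OC)cc1N(C)CCN(C)C` gives 12%
compound 2 `C=CC(=O)Nc1cc(Nc2ncc(F)c(Nc3ccccc3S(=O)(=O)N(C)C)n2)c(OC)cc1N(C)CCN(C)C` gives 10%

Among the measured compounds shown here, in an ADME assay on microsomes from liver (Mus musculus) for metabolic stability, read by LC-MS, using NADPH, with a stated time of 30 min, tested at 1 uM (a lower number here means that less of the compound is left, a higher number that more of the compound is left), compound 2 gives 10% and stands within the scatter of compound 1 at 12% on the numbers so far. For the measured compounds named here, compound 3 `C=CC(=O)Nc1cc(Nc2nccc(Nc3ccccc3S(=O)(=O)N(C)C)n2)c(OC)cc1N(C)CCN(C)C` carries hydrogen in place of fluoro on an aromatic carbon as its only change. Going by the values given here, the one measured step that bears on this altered the group on that same carbon: a number 2 percentage points lower from compound 1 to compound 2 (within the scatter) and on the strength of it no step beyond the scatter is expected in this assay for compound 3 either. The estimated move is a number 2 percentage points higher from compound 2 to compound 3 (within the scatter) and no more. For compound 3 the expected value is 12% with an estimated range from 4% to 25% as the likely span.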

Compound 3, percent of the compound remaining: 5%
Beside the measured number, compound 3's estimate is 7 percentage points above it; the measured number falls inside the stated range.
By their numbers in this assay, from the lowest: compounds 3, 2 and 1 (each within the scatter of the next).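

On this aromatic carbon, hydrogen in place of fluoro gives a number 5 percentage points lower from compound 2 to compound 3 (within the scatter) and hydrogen in place of iodo gives a number 7 percentage points lower from compound 1 to compound 3 (within the scatter) in this assay so a carbon carrying no heavy atom at all reads the same as one carrying either halogen. Iodo, fluoro and hydrogen therefore cannot be told apart at this position in this test. Nothing at hand explains why these three compounds read alike. From the compounds shown here alone, whether a nitrile, a methoxy group or an amine on this carbon would leave more of the compound remaining stays open.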